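Swapping the amide tail for a fluorophenyl ring

The source may hold more compounds than are shown below. What is called first, only, known or untested is meant among the compounds shown, and "the series" means these compounds.

Compound 2 `CCN1CCCC1CNC(=O)c1cccc(CN2CCN(c3ccccc3OC(C)C)CC2)c1` carries the highest number of the two measured compounds in an assay on Cerebral cortex for binding affinity to Adrenergic receptor alpha-1 (Rattus norvegicus) (on this read-out higher numbers stand for weaker inhibition and lower numbers for stronger inhibition), where compound 2 gives 486 nM. Its nearest neighbour, compound 1 `CC(C)Oc1ccccc1N1CCN(Cc2cccc(C(=O)N3CCCCCCC3)c2)CC1`, gives 1.9 nM in this assay; the step of a 260-fold higher number from compound 1 to compound 2 (2.41 log units; beyond the scatter) shows how strongly the group on the carbonyl carbon matters here. Compound 3 `CC(C)Oc1ccccc1N1CCN(Cc2cccc(C(=O)Nc3ccc(F)cc3)c2)CC1` changes that same region once more: 4-fluorophenyl in place of (1-ethylpyrrolidin-2-yl)methyl on an amide-type nitrogen. Among the compounds with values here, no measured step covers an aromatic group on this amide-type nitrogen, so only the one large step is any guide, and it says that this position can move the number a great deal in either direction. A step back toward compound 1 seems more likely than a further rise, and the estimated step of a 12-fold lower number from compound 2 to compound 3 (1.08 log units; beyond the scatter) is expected to fall short of the full gap. Compound 3 is therefore expected to give about 40 nM in this assay, within a wide range from 6 nM to 300 nM.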

Compound 3, inhibition constant: 11 nM
Estimate against measurement, compound 3: 3.6-fold (0.56 log units) above, and the stated range covers the measured number.
By their numbers in this assay, from the lowest: compound 1; then compound 3; then compound 2.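

Replacing (1-ethylpyrrolidin-2-yl)methyl with 4-fluorophenyl on the amide-type nitrogen gives a 44-fold lower number from compound 2 to compound 3 (1.65 log units; beyond the scatter) in this assay, so this position can also hold an aromatic ring and still give a low number. Within the data shown here, compound 3 keeps the amide hydrogen, as compound 2 does, so that hydrogen alone does not bring a number as high as the one for compound 2, although a modest gap remains in a 5.8-fold higher number from compound 1 to compound 3 (0.76 log units; beyond the scatter). Nothing available explains why these groups give such different numbers.

Going by these compounds, it remains open whether the fluorine matters, which a plain phenyl group on the same nitrogen would test. A benzyl group there could also show whether the aromatic ring must sit directly on that nitrogen.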